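A few compounds are considered here, and "the series" means these few. Any claim that something is new, unique, unknown or untested is made for them only; others in the source may bear on it.

Measured in an ADME assay on microsomes from liver (Homo sapiens) for metabolic stability; on this read-out higher numbers stand for a longer-lived compound and lower numbers for a shorter-lived compound:
- compound 1 `COc1nc2ccc(Br)cc2cc1[C@@H](c1cc(C)c(C)s1)[C@@](O)(CCN(C)C)c1cccc(F)c1`: 1 h
- compound 2 `COc1nc2ccc(Br)cc2cc1[C@@H](c1ccnc(OC)c1OC)[C@@](O)(CCN(C)C)c1cccc(C)c1`: 0.867 h
- compound 3 `COc1nc2ccc(Br)cc2cc1[C@@H](c1ccnc(OC)c1OC)[C@@](O)(CCN(C)C)c1cccc(OC(F)F)c1`: 1.02 h

Compound 3, at 1.02 h, lies within the scatter of both other compounds, so these numbers give no ranking among them. Compound 4 `COc1nc2ccc(Br)cc2cc1[C@@H](c1ccnc(OC)c1OC)[C@@](O)(CCN(C)C)c1cccc(C#N)c1` keeps the rest of compound 3 and changes one group: cyano in place of difluoromethoxy on an aromatic carbon.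

Going by the values given here, only one measured step bears on this change. In it, difluoromethoxy took the place of methyl on an aromatic carbon, and the result was a 1.2-fold higher number from compound 2 to compound 3 (0.07 log units; within the scatter). Among the compounds with values here, that is a small step, but it is a single example, and no measured compound carries a cyano group. The expectation is therefore only a cautious one, with no shift beyond the scatter in either direction.

The expected change is a 1.0-fold lower number from compound 3 to compound 4 (0.01 log units; within the scatter).

For compound 4, the estimated half-life is 1 h, with an expected range of 0.5 h to 2 h.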

Compound 4, half-life: 0.617 h
Compound 4: the middle estimate sits 1.6-fold (0.21 log units) above what was measured; the range from low to high includes it.
By their numbers in this assay, from the lowest: compounds 4, 2, 1 and 3 (each within the scatter of the next).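

The 3-cyanophenyl group of compound 4 brings a nitrile to this place on the aromatic ring, and this assay shows a 1.7-fold lower number from compound 3 to compound 4 (0.22 log units; within the scatter) and a 1.4-fold lower number from compound 2 to compound 4 (0.15 log units; within the scatter). Methyl, difluoromethoxy and cyano have now been compared here on an otherwise identical structure, and all the steps between them stay within the scatter, so this read-out does not separate these three groups. There is no evidence here on what lies behind these numbers.

Still open, from the compounds shown here alone, is whether a different group at this place, such as an amine or a carboxylic acid, would give a step beyond the scatter. Also open, going by these compounds, is whether cyano would give a similar result on a structure like compound 1, which differs elsewhere as well.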